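The source may report more compounds than this note shows. Statements on the series, on what has been measured and on what is new or still open speak of the compounds shown alone.

Measured compounds in a functional assay on HeLa cells (Homo sapiens) for antiproliferative activity, read by sulforhodamine B assay, with a stated time of 72 h; a higher number here means a weaker inhibitor, a lower number a stronger inhibitor:
Compound 1 `COc1ccc(C)cc1NC(=S)N/N=C/c1ccc2ccccc2n1` gives only a limit, > 100000 nM.
Compound 2 `Fc1cccc(NC(=S)N/N=C/c2ccc3ccccc3n2)c1` gives 70100 nM.
Compound 3 `CN(C)C(=S)N/N=C/c1cnc2ccccc2n1` gives 750 nM.

Among the numbers that are numbers rather than limits, compound 2 stands highest: compound 3 sits far lower, well beyond the scatter of repeat measurements. Compound 1 shows only the limit (the limit of > 100000 nM in this assay, at which 1 of the 3 values shown sits).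

Compound 4 `Fc1ccccc1NC(=S)N/N=C/c1ccc2ccccc2n1` differs from compound 2 in one place: 2-fluorophenyl in place of 3-fluorophenyl on an amide-type nitrogen. Among the measured compounds shown here, no measured pair shows a change of this kind, so the expected step in this assay rests on the neighbours alone. Compound 1, also carrying a substituted phenyl on that nitrogen, sits at the limit, while compound 2 is weak. For compound 4 a small step is expected, a 1.3-fold higher number from compound 2 to compound 4 (0.11 log units; within the scatter), towards a weaker inhibitor. Compound 4 is estimated at 90000 nM, between 25000 nM and 300000 nM.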

Compound 4, half-maximal inhibitory concentration: > 100000 nM
Compound 4 was reported as a limit (the forecaster's own chance of this, stated with the estimate: 35%); middle value at least 1.1-fold (0.04 log units) away from the limit.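

Among the compounds shown here, this is the first measured swap of 3-fluorophenyl for 2-fluorophenyl on this amide-type nitrogen, and in this assay it gives an at least 1.4-fold higher number from compound 2 to compound 4 (0.15 log units; that floor lies within the scatter). Compound 4 gives a limit rather than a number, so this step is only a floor and its full size cannot be read: the limit of > 100000 nM in this assay, at which 2 of the 4 values shown sit.

What the compounds shown leave open is how a plain phenyl or a longer alkyl chain on this nitrogen would behave with the same core. Also open, on these data alone, is whether a morpholine there would move the result away from the limit.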